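Dimethylamino in place of propoxy: an expected inactive step

The source may report more compounds than this note shows. Statements on the series, on what has been measured and on what is new or still open speak of the compounds shown alone.

Three compounds share one core. Compound 1 `CCOC(=O)c1c(-c2cccc(C)c2)[nH]c2cc(OC)ccc2c1=O` carries a methyl group, compound 2 `CCOC(=O)c1c(-c2cccc(OC)c2)[nH]c2cc(OC)ccc2c1=O` a methoxy group and compound 3 `CCCOc1cccc(-c2[nH]c3cc(OC)ccc3c(=O)c2C(=O)OCC)c1` a propoxy group on the same aromatic carbon. In an ADME assay on Raji cells (Homo sapiens) for cytotoxicity, read by luminescence, with a stated time of 72 h (on this read-out lower numbers stand for an effect already at smaller amounts and higher numbers for an effect only at larger amounts of compound), compound 1 gives only a limit, > 21500 nM. In this assay compound 2 likewise gives only a limit, > 21500 nM. In this assay compound 3 also gives only a limit, > 21500 nM. The steps a step that the two limits leave unreadable from compound 1 to compound 3 and a step that the two limits leave unreadable from compound 2 to compound 3 therefore cannot be sized, since (the limit of > 21500 nM in this assay, at which 3 of the 3 values shown sit). Compound 4 `CCOC(=O)c1c(-c2cccc(N(C)C)c2)[nH]c2cc(OC)ccc2c1=O` differs from compound 3 by dimethylamino in place of propoxy on an aromatic carbon. With every neighbour at the limit, the step from compound 3 to compound 4 is expected as a number no higher from compound 3 to compound 4 (the limit leaves the size open). Compound 4 is expected to give 21500 nM, between 7000 nM and 60000 nM, most likely again as a limit.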

Compound 4, half-maximal effective concentration: > 21500 nM
Compound 4 ended at the assay's limit; the forecaster's own chance of this, stated with the estimate: 80%; the middle value sits exactly at the limit.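

The steps among compound 1, compound 2, compound 3 and compound 4 cannot be read, since each value is only a limit: the limit of > 21500 nM in this assay, at which 4 of the 4 values shown sit.

The compounds shown leave open whether these four groups differ at all in this assay.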